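Side-chain change from compound 2 to compound 3

A few compounds are considered here, and "the series" means these few. Any claim that something is new, unique, unknown or untested is made for them only; others in the source may bear on it.

In a functional assay on HCT-116 cells (Homo sapiens) for cytotoxicity, read by MTT assay, with a stated time of 72 h (on this read-out higher numbers stand for weaker inhibition and lower numbers for stronger inhibition), compound 1 (`COc1ncc(-c2ccc3nc(NC(=O)NCCN4CCCCC4)nn3c2)cc1NS(=O)(=O)c1ccc(F)cc1`) gives 150 nM and compound 2 (`COc1ncc(-c2ccc3nc(NC(=O)NCC(=O)N4CCOCC4)nn3c2)cc1NS(=O)(=O)c1ccc(F)cc1`) gives 490 nM as the higher of the two numbers, so compound 2 is the weaker of this pair. Compound 3 (`COc1ncc(-c2ccc3nc(NC(=O)NCCN4CCN(C)CC4)nn3c2)cc1NS(=O)(=O)c1ccc(F)cc1`) has not yet been measured. Its difference from compound 2 is (4-methylpiperazin-1-yl)methyl in place of (morpholin-4-yl)carbonyl on a saturated chain carbon bound to an amide-type nitrogen and this places (4-methylpiperazin-1-yl)methyl where (morpholin-4-yl)carbonyl stood, on a saturated chain carbon bound to an amide-type nitrogen.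

Among the measured compounds shown here, the one measured step that bears on this is a 3.3-fold higher number from compound 1 to compound 2 (0.51 log units; beyond the scatter) which is modest but beyond the scatter, and it put (morpholin-4-yl)carbonyl in place of (piperidin-1-yl)methyl at the same place. Compound 3 gives up the same (morpholin-4-yl)carbonyl, so most of that step should be undone, towards a lower number. For the measured compounds named here, no measured pair compares (4-methylpiperazin-1-yl)methyl with (piperidin-1-yl)methyl directly, which leaves the range wide. The expected step is a 2.7-fold lower number from compound 2 to compound 3 (0.43 log units; beyond the scatter) and is estimated to be modest in size. The estimate for compound 3 is 180 nM (expected range 70 nM to 450 nM).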

Compound 3, half-maximal inhibitory concentration: 260 nM
Estimate against measurement, compound 3: 1.4-fold (0.16 log units) below, within the range that was stated.
By their numbers in this assay, from the lowest: compounds 1, 3 and 2 (each within the scatter of the next, the first and the last beyond it).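

In this assay the exchange of (morpholin-4-yl)carbonyl for (4-methylpiperazin-1-yl)methyl on a saturated chain carbon bound to an amide-type nitrogen gives a 1.9-fold lower number from compound 2 to compound 3 (0.28 log units; within the scatter) and so cannot be told apart from no change, which means that the gap in a 3.3-fold higher number from compound 1 to compound 2 (0.51 log units; beyond the scatter) does not reappear with every group replacing the carbonyl. Among the compounds shown here, the exchange of piperidin-1-yl for 4-methylpiperazin-1-yl is the first comparison of two rings on the same chain, and it gives a 1.7-fold higher number from compound 1 to compound 3 (0.24 log units; within the scatter) so that compound 3 cannot be separated from compound 1 or compound 2 even though these two lie beyond the scatter of each other. No measurement among these compounds offers an explanation for these numbers.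

With three compounds, the series cannot show whether the ring at the end of this chain matters more than the carbonyl in the chain, since compound 3 falls within the scatter of both neighbours. Open as well is how this position responds to a group of another kind, such as a primary amine, a carboxylic acid or a longer chain carrying the piperidin-1-yl ring.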